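From Cyano to Chloro in a Cell Tolerance Test

The source may report more compounds than this note shows. Statements on the series, on what has been measured and on what is new or still open speak of the compounds shown alone.

Measured so far:
- compound 1 (`Cc1cc(CNS(=O)(=O)c2ccc(C#N)cc2)c(C)o1`) gives 105000 nM
- compound 2 (`Cc1cc(CNS(=O)(=O)c2ccc(C#N)cc2)c(C)s1`) gives > 217000 nM

In an ADME assay on MDCK cells (Canis lupus familiaris) for cytotoxicity, read by MTT assay, with a stated time of 24 h (a higher number here means that more compound is tolerated, a lower number that less compound is tolerated), compound 1 gives 105000 nM as a true number. Compound 2 gives > 217000 nM as a limit and not a number. On these data alone, compound 2 therefore stands at the limit of > 217000 nM in this assay, at which 1 of the 2 values shown sits, and its exact value stays unknown.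

Compound 3 (`Cc1cc(CNS(=O)(=O)c2ccc(Cl)cc2)c(C)s1`) keeps the rest of compound 2 and carries chloro in place of cyano on an aromatic carbon. That carbon sits on a six-membered aromatic ring of carbon only, para to a large group. Going by the values given here, no measured pair of compounds shows what this exchange does, so any forecast here is uncertain. The step of an at least 1.4-fold lower number from compound 2 to compound 3 (0.16 log units; that floor lies within the scatter) is expected to be small and downward, probably within the usual scatter. Among the compounds with values here, the only true number so far belongs to compound 1 at 105000 nM and it anchors the lower side of this expectation. In this assay compound 3 is expected at 150000 nM (estimated range 60000 nM to 300000 nM).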

Compound 3, half-maximal cytotoxic concentration: 52900 nM
Compound 3: the middle estimate sits 2.8-fold (0.45 log units) above what was measured; measured number outside the range, below it.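

In this assay, going by these compounds alone, the exchange of cyano for chloro on this aromatic carbon, para to a large group, gives the first step that can be read: an at least 4.1-fold lower number from compound 2 to compound 3 (0.61 log units; beyond the scatter). The group at this carbon therefore matters for how much compound the cells tolerate, since the rest of the molecule stays the same and the change lies beyond the usual scatter of such measurements. The true size of the step stays unknown, and only its smallest possible size is given, because compound 2 has a limit and not a number: the limit of > 217000 nM in this assay, at which 1 of the 3 values shown sits.

A single exchange on a single core cannot tell whether the lower number comes from gaining chloro or from losing cyano, and it cannot tell whether the same exchange would have a similar effect on the core of compound 1. A plain hydrogen, a methoxy group, an amine or a carboxylic acid on this same carbon would show whether tolerance follows a broader trend across groups or whether chloro stands apart.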